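Swapping Phenethyl for Phenyl: an Expected Acid Dissociation Constant

A few compounds are considered here, and "the series" means these few. Any claim that something is new, unique, unknown or untested is made for them only; others in the source may bear on it.

Compound 1, `c1ccc(CCc2ccc3c(NCCCNCc4ccco4)ccnc3c2)cc1`: 9.47
Compound 2, `COc1cccc(CNCCCNc2ccnc3cc(Cc4cc(C)cc(C)c4)ccc23)c1O`: 9.47
Compound 3, `COc1ccc(Oc2ccc3c(NCCCNCc4cccc(OC)c4O)ccnc3c2)cc1`: 9.28

Of the compounds shown here, three of a shared core have been measured in a physicochemical assay for acid dissociation. Compound 1 stands level with compound 2 at the digits given, and the two are together the highest of the three numbers; compound 3 sits lower, but only by an amount within the scatter. Within the data shown here, the one step among measured compounds that differ in a single place is a number 0.19 log units lower from compound 2 to compound 3 (within the scatter), where a group on an aromatic carbon far from the amine chain was exchanged and the read-out did not move beyond the scatter.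

The unmeasured compound 4, `c1ccc(-c2ccc3c(NCCCNCc4ccco4)ccnc3c2)cc1`, differs from compound 1 as follows: phenyl in place of phenethyl on an aromatic carbon. This exchange sits on the same kind of remote aromatic carbon as the change from compound 2 to compound 3, and neither group leaving nor entering carries a hydrogen-bond donor or acceptor. Because that earlier step was a number 0.19 log units lower from compound 2 to compound 3 (within the scatter), no change beyond the scatter is expected here either.

Compound 4 is therefore estimated at 9.45, with a range of 9.15 to 9.75, meaning an expected step of a number 0.02 log units lower from compound 1 to compound 4 (within the scatter).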

Compound 4, acid dissociation constant: 9.47
Beside the measured number, compound 4's estimate is 0.02 log units below it, within the range that was stated.
By their numbers in this assay, from the lowest: compounds 3, 1, 2 and 4 (each within the scatter of the next).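

In this assay, phenyl in place of phenethyl on the aromatic carbon gives no change at the digits printed from compound 1 to compound 4 (within the scatter) even though the group shrinks from 8 heavy atoms to 6 and the phenyl ring now sits directly on the shared core. The earlier step, a number 0.19 log units lower from compound 2 to compound 3 (within the scatter) with another amine side chain, exchanged 3,5-dimethylbenzyl for 4-methoxyphenoxy, so this new pair extends the same flat reading at this position to a second side chain and to two groups made of carbon only. No measurement shown here offers an explanation for the flat result.

Among these compounds, all the groups seen at this position so far are built around a six-membered aromatic ring, so it remains open whether an amine, a carboxylic acid or a longer chain on this carbon would also leave the number within the scatter. Going by these compounds, it also remains open whether phenyl in place of phenethyl would give the same result on the amine side chain of compound 2.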